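The compounds below may be only part of what the source reports. "The series", "measured", "known", "first", "only" and "open" are said of these compounds alone.

Compound 1 `CCCCCC1(OC)CCN(c2ccc(C(=O)NS(=O)(=O)c3ccc(N[C@H](CCN(C)C)CSc4ccccc4)c([N+](=O)[O-])c3)cc2)CC1`: 3000 nM
Compound 2 `CN(C)CC[C@H](CSc1ccccc1)Nc1ccc(S(=O)(=O)NC(=O)c2ccc(N3CCN(C(=O)Nc4ccccc4)CC3)cc2)cc1[N+](=O)[O-]`: > 50000 nM

In a functional assay (FL5.12 cells, Mus musculus) with Apoptosis regulator Bcl-2 (Homo sapiens) as the target (a higher number here means that more compound is needed for the effect, a lower number that less compound is needed), compound 1 gives 3000 nM. For compound 2 the assay reports only a limit, > 50000 nM, so compound 2 stands at the limit of > 50000 nM in this assay, at which 1 of the 2 values shown sits, and its true value is not known. Compound 3 `CN(C)CC[C@H](CSc1ccccc1)Nc1ccc(S(=O)(=O)NC(=O)c2ccc(N3CCN(Cc4ccccc4S(C)(=O)=O)CC3)cc2)cc1[N+](=O)[O-]` differs from compound 2 in one place: 2-(methylsulfonyl)benzyl in place of phenylcarbamoyl on an amine nitrogen in a ring. For the measured compounds named here, no measured pair shows what such a change does here. A step from compound 2 to compound 3 of an at least 5.0-fold lower number from compound 2 to compound 3 (0.69 log units; beyond the scatter) is expected, toward less compound needed. Compound 3 is estimated at 10000 nM, with a range from 2000 nM to 50000 nM, and a real chance that only a limit is reported again.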

Compound 3, half-maximal effective concentration: 6800 nM
Compound 3: the middle estimate sits 1.5-fold (0.17 log units) above what was measured, and the stated range covers the measured number.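

On an amine nitrogen in a ring, 2-(methylsulfonyl)benzyl in place of phenylcarbamoyl gives, in this assay, an at least 7.3-fold lower number from compound 2 to compound 3 (0.86 log units; beyond the scatter). This shows that the group at this position matters, and that a measurable number can be reached here with a group that has no hydrogen-bond donor. Compound 2 is only a limit, so the step has a floor but no known size: the limit of > 50000 nM in this assay, at which 1 of the 3 values shown sits.

The compounds shown do not separate the part played by the methylsulfonyl from that of the benzyl link. A plain benzyl would help to tell them apart.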